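A few compounds are considered here, and "the series" means these few. Any claim that something is new, unique, unknown or untested is made for them only; others in the source may bear on it.

Among the measured compounds shown here, compound 2 `Cc1cc(C)cc(-n2nncc2CN2C(=O)C3(C(C#N)=C(N)Oc4c(N)cc5nc6ccccc6nc5c43)c3ccccc32)c1` holds the only plain number here: in a functional assay on A549 cells (Homo sapiens) for antiproliferative activity, read by MTT assay, with a stated time of 48 h (on this read-out lower numbers stand for stronger inhibition and higher numbers for weaker inhibition), compound 2 gives 31200 nM. Compound 1 `N#CC1=C(N)Oc2c(N)cc3nc4ccccc4nc3c2C12C(=O)N(Cc1cnnn1-c1ccc(Cl)cc1)c1ccccc12` reaches only a limit of the assay, > 50000 nM, and that limit is described as the limit of > 50000 nM in this assay, at which 1 of the 2 values shown sits. Compound 3 `COc1cc(-n2nncc2CN2C(=O)C3(C(C#N)=C(N)Oc4c(N)cc5nc6ccccc6nc5c43)c3ccccc32)c(OC)cc1Cl` carries 4-chloro-2,5-dimethoxyphenyl in place of 3,5-dimethylphenyl on an aromatic nitrogen. For the measured compounds named here, the single measured step at this same aromatic nitrogen, an at least 1.6-fold lower number from compound 1 to compound 2 (0.20 log units; that floor lies within the scatter), is the only guide, and its floor lies within the scatter. The expected step is therefore no larger than the scatter: a 1.0-fold lower number from compound 2 to compound 3 (0.02 log units; within the scatter). Compound 3 is estimated at 30000 nM, with a range from 12000 nM to 80000 nM.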

Compound 3, half-maximal inhibitory concentration: > 50000 nM
Compound 3: no number, only a limit (the forecaster's own chance of this, stated with the estimate: 30%); middle value at least 1.6-fold (0.22 log units) away from the limit.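

Putting 4-chloro-2,5-dimethoxyphenyl in place of 3,5-dimethylphenyl on the aromatic nitrogen gives an at least 1.6-fold higher number from compound 2 to compound 3 (0.20 log units; that floor lies within the scatter). So the added methoxy groups and chlorine bring no measurable gain here, and the step from compound 1 to compound 3 cannot be read, since both end at a limit rather than a number. Of these three aryl groups, only 3,5-dimethylphenyl gives a plain number, and the others stop at the same limit: the limit of > 50000 nM in this assay, at which 2 of the 3 values shown sit.

Three compounds show no trend across the aryl groups. Going by these compounds, it remains open whether a phenyl ring carrying an amine or a carboxylic acid, or a benzyl group, on this nitrogen would give a clearly lower number.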